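Fluoro in place of hydrogen: compound 1 to compound 4

A few compounds are considered here, and "the series" means these few. Any claim that something is new, unique, unknown or untested is made for them only; others in the source may bear on it.

Measured compounds in the series:
compound 1, `c1ccc(-c2nnc(Nc3ncccn3)o2)cc1`: 51.4%
compound 2, `COc1cc(-c2nnc(Nc3ncccn3)o2)cc(OC)c1OC`: 57.7%
compound 3, `Oc1ccccc1-c1nnc(Nc2ncccn2)o1`: 58.8%

In a functional assay, with a stated time of 30 min, tested at 20 uM (a higher number here means more inhibition at the concentration tested (going by the name of the read-out), a lower number less inhibition), compound 1 gives 51.4%, the lowest of the three numbers. The nearest is compound 2 with 57.7% and the furthest is compound 3 with 58.8%; both gaps are within the scatter, so the three measured compounds sit at one level, and no word of order between them is warranted. Among the measured compounds shown here, the only single-point step among them is a number 7.4 percentage points higher from compound 1 to compound 3 (within the scatter), the change being hydroxy in place of hydrogen on an aromatic carbon.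

Compound 4, `Fc1ccc(-c2nnc(Nc3ncccn3)o2)cc1`, differs from compound 1 by fluoro in place of hydrogen on an aromatic carbon. For the measured compounds named here, the one step that bears on it is the hydroxy step, which stayed within the scatter; compound 2, with three methoxy groups on the same ring, also shows a value within the scatter of compound 1. Going by the values given here, nothing among the measured compounds points to a change beyond the scatter from a single small substituent on this ring, so for compound 4 the expected step is a number 1.6 percentage points higher from compound 1 to compound 4 (within the scatter), none beyond the scatter. Compound 4 is thus estimated to give 53% in this assay, with a range from 40% to 66%.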

Compound 4, a percentage reported as inhibition, at one concentration (the size of the read-out at that concentration, not a potency): 41.9%
Beside the measured number, compound 4's estimate is 11.1 percentage points above it; measured number inside the range.
By their numbers in this assay, from the lowest: compounds 4, 1, 2 and 3 (each within the scatter of the next, the first and the last beyond it).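

In this assay, the place para to a large group on the six-membered aromatic ring of carbon only now has a reading of its own: fluoro in place of hydrogen there gives a number 9.5 percentage points lower from compound 1 to compound 4 (within the scatter) and so stays inside the usual spread of repeat measurements. Set against a number 7.4 percentage points higher from compound 1 to compound 3 (within the scatter) for hydroxy in place of hydrogen, the new step is printed in the opposite direction, yet neither step lies beyond the scatter, so neither change can be given a direction on the present numbers, and the series still has no single-place change that clearly moves the read-out. No measurement at hand accounts for the size of the fluoro step.

Going by these compounds, whether chloro, methyl, an amine or a carboxylic acid at this same place would give a step beyond the scatter remains open. Also open, on these data alone, is whether hydroxy at this place would read as fluoro does, and whether a change elsewhere on the shared core would move the read-out further than either substitution on this ring.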